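The compounds below may be only part of what the source reports. "The series", "measured", "known", "first", "only" and "open" are said of these compounds alone.

Measured compounds:

Compound 1, `Nc1cc(N)c2nc(-c3ccccc3)c(Oc3ccc(Cl)c(Cl)c3)nc2c1`: 10200 nM
Compound 2, `Nc1cc(N)c2nc(-c3ccccc3)c(NCc3ccc(Cl)c(Cl)c3)nc2c1`: 1580 nM
Compound 3, `COc1cc(CNc2nc3cc(N)cc(N)c3nc2-c2ccccc2)cc(OC)c1OC`: 7240 nM

These three were tested in a functional assay on MDA-MB-231 cells (Homo sapiens) for inhibition, read by sulforhodamine B assay, with a stated time of 48 h; a lower number here means a stronger inhibitor of growth, a higher number a weaker inhibitor of growth. Compound 1 gives the highest number of the three. The gap to compound 3 is within the scatter, so the two cannot be told apart; compound 2 gives a number well below that of compound 1, a gap beyond the scatter.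

Compound 4, `Nc1cc(N)c2nc(-c3ccccc3)c(Oc3ccc(F)cc3)nc2c1`, has not yet been measured. It differs from compound 1 in one place: 4-fluorophenyl in place of 3,4-dichlorophenyl on an oxygen on an aromatic ring. Within the data shown here, no measured pair shows the effect of this exchange, so the direction of the step rests on expectation only. With a smaller halogen-bearing ring taking the place of the dichlorinated one, the expected outcome is a step about the size of the scatter or a little beyond it, toward a higher number, that is, toward weaker growth inhibition, as a 1.6-fold higher number from compound 1 to compound 4 (0.20 log units; within the scatter). On that basis compound 4 is expected to give 16000 nM in this assay, with a range from 5000 nM to 50000 nM.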

Compound 4, concentration for 50% growth inhibition: 3890 nM
Compound 4: the middle estimate sits 4.1-fold (0.61 log units) above what was measured; measured number outside the range, below it.
By their numbers in this assay, from the lowest: compound 2; then compounds 4, 3 and 1 (each within the scatter of the next, the first and the last beyond it).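

In this assay, putting 4-fluorophenyl in place of 3,4-dichlorophenyl on an oxygen on an aromatic ring gives a 2.6-fold lower number from compound 1 to compound 4 (0.42 log units; beyond the scatter), a modest gain in growth inhibition. Among these compounds, this is the first pair that differs in one place, and it shows that the group on this oxygen affects the result and that the two chlorines are not required for growth inhibition in these cells. Nothing available explains why the number falls.

This single pair cannot separate the loss of the two chlorines from the gain of the fluorine. Plain phenyl and 4-chlorophenyl on the same oxygen would tell those two parts apart, while a 4-methoxyphenyl would test a substituent that is not a halogen.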